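This account rests on a few compounds, and the source may have more. Where it says the series, first, only, none or still open, it means among the compounds named here.

Measured so far in a functional assay on SK-OV-3 cells (Homo sapiens) for inhibition, read by MTT assay; a lower number here means a stronger inhibitor, a higher number a weaker inhibitor:
- compound 1 `COc1ccc(/C=C2\c3cc(OC)c(OC)c(OC)c3CC[C@H]2O)cc1F`: 720 nM
- compound 2 `COc1ccc(/C=C2\c3cc(OC)c(OC)c(OC)c3CC[C@H]2O)cc1N`: 1870 nM
- compound 3 `COc1ccc(/C=C2\c3cc(OC)c(OC)c(OC)c3CC[C@H]2O)cc1O`: 1590 nM

These three differ in a single group on one aromatic carbon. Compound 3, at 1590 nM, cannot be told apart from its nearest neighbour, as the gap is only a 1.2-fold lower number from compound 2 to compound 3 (0.07 log units; within the scatter). The gap to its furthest neighbour is clearer: a 2.2-fold higher number from compound 1 to compound 3 (0.34 log units; beyond the scatter).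

The next structure, compound 4 `COc1ccc(/C=C2\c3cc(OC)c(OC)c(OC)c3CC[C@H]2O)cc1[N+](=O)[O-]`, carries nitro in place of hydroxy on an aromatic carbon. Going by the values given here, no measured compound has a nitro group, so its direction cannot be read from the data. Among the compounds with values here, the swaps already made at this carbon are the only guide. Two were modest, a 2.6-fold higher number from compound 1 to compound 2 (0.41 log units; beyond the scatter) and a 2.2-fold higher number from compound 1 to compound 3 (0.34 log units; beyond the scatter), and the third, a 1.2-fold lower number from compound 2 to compound 3 (0.07 log units; within the scatter), was lost in the scatter. A small step in this assay is therefore expected, with only a slight lean towards a lower number.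

The expected step is a 1.3-fold lower number from compound 3 to compound 4 (0.12 log units; within the scatter).

Compound 4 is estimated at 1200 nM, with an expected range of 450 nM to 3200 nM.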

Compound 4, half-maximal inhibitory concentration: > 10000 nM
Compound 4 gave a limit, no number (the forecaster's own chance of this, stated with the estimate: 2%); middle value at least 8.3-fold (0.92 log units) away from the limit.
By their numbers in this assay, from the lowest: compound 1; then compounds 3 and 2 (each within the scatter of the next). At a limit, above all of these: compound 4.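

In this assay, the reading for compound 4 is a limit and not a number: the limit of > 10000 nM in this assay, at which 1 of the 4 values shown sits. Earlier swaps at this aromatic carbon gave modest steps or none beyond the scatter, but nitro gives far larger ones: in place of hydroxy an at least 6.2-fold higher number from compound 3 to compound 4 (0.79 log units; beyond the scatter), in place of amino an at least 5.3-fold higher number from compound 2 to compound 4 (0.72 log units; beyond the scatter), and in place of fluoro an at least 13-fold higher number from compound 1 to compound 4 (1.14 log units; beyond the scatter). This position is therefore much less forgiving than the first three compounds suggested, since one swap here can take a compound from a measurable inhibitor to one that reaches the limit of the assay.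

The four compounds cannot say why nitro differs so sharply from fluoro, amino and hydroxy, and the full size of these steps stays unknown. From the compounds shown here alone, whether a nitrile, a carboxylic acid or a methyl group at this carbon would behave like fluoro or like nitro also remains open.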